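Halogen swap on the core of compound 1

The source may report more compounds than this note shows. Statements on the series, on what has been measured and on what is new or still open speak of the compounds shown alone.

Measured compounds:
compound 1 `O=C(NCCCCc1ccccc1)n1c(=O)oc2ccc(Cl)cc21`: 15 nM
compound 2 `Cc1ccc2c(c1)oc(=O)n2C(=O)NCCCCc1ccccc1`: 66 nM

Of the compounds shown here, two have been measured in an assay on HEK293 cells for inhibition of acid ceramidase (Homo sapiens), with a stated time of 10 min; on this read-out lower numbers stand for stronger inhibition and higher numbers for weaker inhibition. Compound 1 gives 15 nM and stands as the lowest of the two numbers; compound 2 gives 66 nM, a higher number, and that gap lies beyond the scatter of the measurement. The two share a core and the same chain on the carbamate, and differ only in the group on the fused aromatic ring.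

Compound 3 `O=C(NCCCCc1ccccc1)n1c(=O)oc2ccc(F)cc21` has not been measured in this assay. It follows from compound 1 by the change (fluoro in place of chloro on an aromatic carbon), that is, fluoro in place of chloro on an aromatic carbon. Going by the values given here, no measured pair shows the same change, so its size is an open question. Compound 3 is expected to give a modestly higher number than compound 1, a step of a 2.0-fold higher number from compound 1 to compound 3 (0.30 log units; within the scatter) that may well stay within the scatter. The estimate for compound 3 is 30 nM, within 10 nM to 90 nM.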

Compound 3, half-maximal inhibitory concentration: 12 nM
Estimate against measurement, compound 3: 2.5-fold (0.40 log units) above, within the range that was stated.
By their numbers in this assay, from the lowest: compounds 3 and 1 (each within the scatter of the next); then compound 2.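

In this assay fluoro in place of chloro on this aromatic carbon gives a 1.3-fold lower number from compound 1 to compound 3 (0.10 log units; within the scatter) and so the two halogens cannot be told apart on this read-out. Going by these compounds alone, this is the first reading of a single swap at this position, and it shows that the position accepts fluoro as well as chloro, with compound 1 and compound 3 standing within the scatter of each other. Nothing shown here gives a reason for this result.

What the compounds leave open is how far this position accepts groups other than these halogens, such as a methoxy group, a nitrile or a trifluoromethyl group. Also open, on these data alone, is how the number responds to the chain of compound 3, whether made shorter or longer or ended with an amine.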